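Swapping Methoxy for Bromo in a Growth-Inhibition Series

The compounds below may be only part of what the source reports. "The series", "measured", "known", "first", "only" and "open" are said of these compounds alone.

In an ADME assay on HaCaT cells (Homo sapiens) for inhibition, read by sulforhodamine B assay, with a stated time of 48 h (on this read-out lower numbers stand for stronger inhibition of growth and higher numbers for weaker inhibition of growth), compound 1 (`S=C(N/N=C/c1cccs1)Nc1ccc(Cl)cc1`) gives 14700 nM. Compound 2 (`COc1ccc(NC(=S)N/N=C/c2cccs2)cc1`) gives only > 100000 nM, which is a limit of the assay and not a true number. As far as these compounds go, compound 2 therefore sits at the weak end of the two compounds measured so far, and its exact value is unknown.

Compound 3 (`S=C(N/N=C/c1cccs1)Nc1ccc(Br)cc1`) differs from compound 2 by a single change: bromo in place of methoxy on an aromatic carbon. In words, this is bromo in place of methoxy on an aromatic carbon. Among the measured compounds shown here, only one measured step bears on it: an at least 6.8-fold higher number from compound 1 to compound 2 (0.83 log units; beyond the scatter), where methoxy took the place of chloro on the same kind of carbon. Compound 3 removes that methoxy and has bromo where compound 1 has chloro. A step to a lower number in this assay, beyond the scatter and similar in size to that one, is therefore expected, though it rests on one pair alone. The expected change is an at least 7.1-fold lower number from compound 2 to compound 3 (0.85 log units; beyond the scatter). Compound 3 is estimated at 14000 nM, with an expected range of 5000 nM to 40000 nM.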

Compound 3, concentration for 50% growth inhibition: 800 nM
Beside the measured number, compound 3's estimate is 18-fold (1.24 log units) above it; the whole stated range lies above it.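

Among the compounds shown here, at this position, an aromatic carbon para to a large group, the earlier compounds compared only chloro with methoxy, so they could not show whether one halogen would behave like another. In this assay, the two halogens turn out to be far apart: bromo in place of chloro gives an 18-fold lower number from compound 1 to compound 3 (1.26 log units; beyond the scatter), so a change from one halogen to the next at this single place is enough to shift growth inhibition well beyond the scatter. Bromo in place of methoxy gives an at least 120-fold lower number from compound 2 to compound 3 (2.09 log units; beyond the scatter), and that size is only a minimum because compound 2 has a limit and not a true number: the limit of > 100000 nM in this assay, at which 1 of the 3 values shown sits.

For the compounds shown here, with only three groups at this position, nothing yet shows how far the order among them extends, and what fluoro, iodo, an amine or a carboxylic acid would give here remains open. As far as these compounds go, it is also open whether the advantage of bromo over chloro would hold if the shared core were changed elsewhere, since all three compounds carry the same core.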